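Pyrrolidinyl side chain in compound 4: working notes

The compounds below may be only part of what the source reports. "The series", "measured", "known", "first", "only" and "open" are said of these compounds alone.

Measured so far in an assay on isolated protein for inhibition of DNA topoisomerase 1 (Homo sapiens), with a stated time of 15 min; on this read-out higher numbers stand for weaker inhibition and lower numbers for stronger inhibition:
- compound 1 `CNCCCCNc1cc2c(cc1F)c(=O)c(C(=O)O)cn2Cc1ccc(-c2ccccc2)cc1`: 88300 nM
- compound 2 `COc1c(N2CC[C@@H](CO)C2)c(F)cc2c(=O)c(C(=O)O)cn(Cc3ccc(-c4ccccc4)cc3)c12`: the assay limit > 200000 nM, a limit rather than a number
- compound 3 `CNCCCCNc1c(F)cc2c(=O)c(C(=O)O)cn(Cc3ccc(-c4ccccc4)cc3)c2c1OC`: the assay limit > 200000 nM, again a limit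

For the measured compounds named here, compound 1 stands as the only compound with a number in this assay; the other two values sit at the limit of > 200000 nM in this assay, at which 2 of the 3 values shown sit. The step of an at least 2.2-fold higher number from compound 1 to compound 3 (0.35 log units; beyond the scatter) shows weaker inhibition on adding the methoxy group, and the step that the two limits leave unreadable from compound 2 to compound 3 cannot be sized from two limits.

Compound 4 `O=C(O)c1cn(Cc2ccc(-c3ccccc3)cc2)c2cc(NC[C@H]3CCNC3)c(F)cc2c1=O` differs from compound 1 only in the side chain: pyrrolidin-3-yl in place of 3-(methylamino)propyl on a saturated chain carbon bound to a nitrogen on an aromatic ring. Going by the values given here, no measured step touches this side chain, so the record gives no direct guide. With the rest of the structure held as in compound 1, and one comparable change (the methoxy) costing only a modest step, the expectation for compound 4 is no step beyond the scatter, i.e. a 1.1-fold higher number from compound 1 to compound 4 (0.05 log units; within the scatter). Compound 4 is thus estimated at 100000 nM, with a range from 40000 nM to 250000 nM.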

Compound 4, half-maximal inhibitory concentration: 100000 nM
Beside the measured number, compound 4's estimate shows no gap at the digits printed, and the stated range covers the measured number.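

In this assay, the open 3-(methylamino)propyl chain gives way to the pyrrolidin-3-yl ring on a saturated chain carbon bound to a nitrogen on an aromatic ring, with a 1.1-fold higher number from compound 1 to compound 4 (0.05 log units; within the scatter), so the two compounds read alike and this place accepts the ring in place of the chain. For the compounds shown here, the earlier compounds could not show this: the only earlier step that changes a side chain, from compound 2 to compound 3, runs between two limits and cannot be read. Compound 2 and compound 3 remain limits rather than numbers, while compound 4 gives a number, as compound 1 does: the limit of > 200000 nM in this assay, at which 2 of the 4 values shown sit.

Open, from the compounds shown here alone, is whether a larger ring such as piperidin-3-yl, or a methyl group on the pyrrolidine nitrogen as in 1-methylpyrrolidin-3-yl, would read differently. Also open, going by these compounds, is how the opposite configuration at the defined stereocentre of pyrrolidin-3-yl would read.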